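Swapping an aminomethyl for a 1-aminocyclopentyl on the amide

This account rests on a few compounds, and the source may have more. Where it says the series, first, only, none or still open, it means among the compounds named here.

Of the compounds shown here, two from one series have been measured in a functional assay on NCI-H1975 cells (Homo sapiens) for antiproliferative activity; on this read-out lower numbers stand for stronger inhibition and higher numbers for weaker inhibition. Compound 1 `Cc1c2c(n3c1CCN(C(=O)CN)C[C@@H](C)[C@H](C)Nc1cc-3ccc1C(N)=O)CC(C)(C)CC2=O` gives 190 nM in this assay, the higher of the two numbers recorded so far. Compound 2 `Cc1c2c(n3c1CCCN(C(=O)CO)[C@@H](C)[C@H](C)Nc1cc-3ccc1C(N)=O)CC(C)(C)CC2=O` gives 54 nM in this assay, a lower number that lies beyond the usual scatter; it differs from compound 1 in more than one place, so no single structural cause can be read from that pair.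

Compound 3 `Cc1c2c(n3c1CCN(C(=O)C1(N)CCCC1)C[C@@H](C)[C@H](C)Nc1cc-3ccc1C(N)=O)CC(C)(C)CC2=O` has not yet been measured. It differs from compound 1 in one place: 1-aminocyclopentyl in place of aminomethyl on a carbonyl carbon. The carbonyl carbon that carries the group stays attached to the same amide-type nitrogen in a ring; only the substituent on that carbon is exchanged. For the measured compounds named here, no measured pair in the data shows the effect of this exchange, so the expectation rests on compound 1 alone. The step from a 1.2-fold lower number from compound 1 to compound 3 (0.07 log units; within the scatter) is expected to be small, likely within the scatter. Compound 3 is therefore estimated at 160 nM in this assay, with a plausible range of 60 nM to 450 nM.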

Compound 3, half-maximal inhibitory concentration: 26 nM
The estimate for compound 3 lay 6.2-fold (0.79 log units) above the measured number; the whole stated range lies above it.
By their numbers in this assay, from the lowest: compound 3; then compound 2; then compound 1.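

Exchanging the group on the carbonyl carbon has a clear effect on this series: in this assay, 1-aminocyclopentyl in place of aminomethyl gives a 7.3-fold lower number from compound 1 to compound 3 (0.86 log units; beyond the scatter), with the rest of the molecule unchanged. For the compounds shown here, this is the first single-place comparison, since compound 1 and compound 2 differ in more than one place and could not show what any one group contributes. The exchange adds carbon atoms and a five-membered ring of carbon only, while the hydrogen-bond donor and acceptor counts and the absence of net charge stay the same, but no measurement here explains why the number falls.

The compounds shown leave open whether the ring itself matters or only the added carbon, a question that an open-chain group such as 1-amino-1-methylethyl, or a ring of another size such as 1-aminocyclohexyl, could help to answer. They also leave open whether the amine is needed, which a plain cyclopentyl group on the same carbonyl carbon would test.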